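This account rests on a few compounds, and the source may have more. Where it says the series, first, only, none or still open, it means among the compounds named here.

The measured compounds in a functional assay on IGROV-1 cells (Homo sapiens) for inhibition, read by sulforhodamine B assay, with a stated time of 48 h, tested at 10 uM; a higher number here means a weaker effect of the compound at the concentration tested, a lower number a stronger effect:
Compound 1 `O=C(Nc1cccc(-n2cc(-c3ccncc3)c(-c3cc(O)cc(Cl)c3)n2)c1)Nc1ccc(Cl)c(Cl)c1` gives 26%.
Compound 2 `COc1cc(Cl)cc(-c2nn(-c3cccc(NC(=O)Nc4ccc(Cl)c(C(F)(F)F)c4)c3)cc2-c2ccncc2)c1` gives 30.2%.
Compound 3 `COc1cc(Cl)cc(-c2nn(-c3cccc(NC(=O)Nc4ccc(Cl)c(Cl)c4)c3)cc2-c2ccncc2)c1` gives 36.7%.

Compound 3 has the highest of the three numbers in this assay, which here means the weakest effect at the concentration tested. Its nearest neighbour is compound 2, and the step of a number 6.5 percentage points higher from compound 2 to compound 3 (within the scatter) lies within the scatter, so these two cannot be told apart. The step of a number 10.7 percentage points higher from compound 1 to compound 3 (beyond the scatter) is beyond the scatter, though modest.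

Compound 4 `COc1cc(Cl)cc(-c2nn(-c3cccc(NC(=O)c4cccc(C(F)(F)F)c4)c3)cc2-c2ccncc2)c1` is not yet measured. It differs from compound 3 in one place: 3-(trifluoromethyl)phenyl in place of (3,4-dichlorophenyl)amino on a carbonyl carbon. The carbonyl carbon, whose other neighbour is an amide-type nitrogen, thus carries 3-(trifluoromethyl)phenyl directly instead of (3,4-dichlorophenyl)amino, and one hydrogen-bond donor is lost.

None of the measured steps touches this part of the molecule; they concern methyl in place of hydrogen on an oxygen on an aromatic ring and chloro in place of trifluoromethyl on an aromatic carbon. a number 6.5 percentage points higher from compound 2 to compound 3 (within the scatter) shows that the second of these stays within the scatter, but removing the amino link is a larger change with no precedent among these compounds. The expectation is therefore uncertain, leaning towards a somewhat higher number, that is a weaker effect, with an estimated step of a number 8.3 percentage points higher from compound 3 to compound 4 (within the scatter). Compound 4 is thus expected to give about 45% in this assay, with a likely range from 25% to 70%.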

Compound 4, a percentage reported as activity, at one concentration (the size of the read-out at that concentration, not a potency): 80.7%
Beside the measured number, compound 4's estimate is 35.7 percentage points below it; measured number outside the range, above it.
By their numbers in this assay, from the lowest: compounds 1, 2 and 3 (each within the scatter of the next, the first and the last beyond it); then compound 4.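

In this assay, putting 3-(trifluoromethyl)phenyl directly on the carbonyl carbon in place of (3,4-dichlorophenyl)amino gives a number 44 percentage points higher from compound 3 to compound 4 (beyond the scatter), and the matching replacement of (4-chloro-3-(trifluoromethyl)phenyl)amino gives a number 50.5 percentage points higher from compound 2 to compound 4 (beyond the scatter). This shows that the effect at the tested concentration is far more sensitive to this change than to the two earlier ones, which gave a number 10.7 percentage points higher from compound 1 to compound 3 (beyond the scatter) and a number 6.5 percentage points higher from compound 2 to compound 3 (within the scatter), although each new step alters the amino link and the substituents on the outer ring together. Nothing measured here accounts for the size of these steps.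

The compounds shown leave open whether the amino link or the ring substituents matter more, since (3-(trifluoromethyl)phenyl)amino on the carbonyl carbon would change only the ring relative to compound 4's parent series, and 3,4-dichlorophenyl directly on that carbon would remove only the link from compound 3. Going by these compounds, it also remains open how a methylene or an oxygen link in the place of the amino group would read in this assay.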